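Trimming the neopentyl chain on a weakly active core

The compounds below may be only part of what the source reports. "The series", "measured", "known", "first", "only" and "open" are said of these compounds alone.

The three measured compounds share one core and all sit at the weak end of a functional assay for inhibition, with Homo sapiens as the target; on this read-out higher numbers stand for weaker inhibition and lower numbers for stronger inhibition. Compound 1 `Cc1nc(C)n2c(S)nncc12` reaches only > 48000 nM, which is a limit of the assay and not a number. Compound 2 `Cc1nc(CC(C)(C)C)n2c(O)nncc12` likewise gives > 48000 nM, again a limit rather than a number. For the measured compounds named here, compound 3 `CCc1nc(C)c2cnn(CC)c(=O)n12` is the one compound with a measured figure, at 75600 nM. Compound 2 thus stands at the limit of > 48000 nM in this assay, at which 2 of the 3 values shown sit. Compound 1 sits there as well, while compound 3 alone carries a number, and that number lies in the same weak region.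

The next compound, compound 4 `Cc1nc(C)n2c(O)nncc12`, differs from compound 2 in one place: hydrogen in place of tert-butyl on a saturated chain carbon bound to an aromatic carbon. No step between two measured compounds is available to size this change, so the expectation rests on the observation that every compound shown, whether a limit or a number, lies in the same weak region. For compound 4 the expected step is a step that the limit leaves unreadable from compound 2 to compound 4, nothing beyond the usual scatter. In this assay compound 4 is estimated at 70000 nM, with a range from 30000 nM to 200000 nM, and it is expected that the assay will most likely again report only a limit.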

Compound 4, half-maximal inhibitory concentration: > 48000 nM
Compound 4: only a limit was reported; the forecaster's own chance of this, stated with the estimate: 75%; the middle value is on the limit's open side.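

In this assay compound 4 gives > 48000 nM as a limit of the assay and not a number. No step can be read from compound 2 to compound 4 or from compound 1 to compound 4, because all three compounds end in a limit: the limit of > 48000 nM in this assay, at which 3 of the 4 values shown sit. On these data alone, whether neopentyl to methyl, or hydroxy in place of sulfanyl, changes inhibition at all stays open.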